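The source may report more compounds than this note shows. Statements on the series, on what has been measured and on what is new or still open speak of the compounds shown alone.

Compound 1 `N/C(=N\NC(=S)N1CCCCCC1)c1ccccn1` and compound 2 `N/C(=N\NC(=S)N1CCOCC1)c1ccccn1` share a thiosemicarbazide-like linker to the same amidine-bearing aromatic core, but the difference between their two cores is not broken down here. In a functional assay on MCF7 cells (Homo sapiens) for cytotoxicity, read by MTT assay, with a stated time of 72 h, tested at 30 uM (a higher number here means more inhibition of growth at the concentration tested, a lower number less inhibition of growth), compound 1 gives 76.5%, and compound 2 gives 78.1%; these two numbers lie within the scatter of each other, so nothing separates them. Compound 3 `N/C(=N\NC(=S)N1CCOCC1)c1ccc(F)cn1` carries the change fluoro in place of hydrogen on an aromatic carbon relative to compound 2, and in this assay compound 3 gives 56.7%. The step of a number 21.4 percentage points lower from compound 2 to compound 3 (beyond the scatter) is the only measured instance of this change among the compounds shown.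

Compound 4 `N/C(=N\NC(=S)N1CCCCCC1)c1ccc(F)cn1` stands to compound 1 as compound 3 stands to compound 2: the change is fluoro in place of hydrogen on an aromatic carbon, made at the same place in the same words. Among the measured compounds shown here, for compound 4 a step of about a number 20.5 percentage points lower from compound 1 to compound 4 (beyond the scatter) is expected, of the same size as the earlier one, because a number 21.4 percentage points lower from compound 2 to compound 3 (beyond the scatter) is the one measured precedent and nothing in the data of compound 1 and compound 2 points to a different response. Compound 4 is therefore estimated at 56%, with a range from 42% to 68%.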

Compound 4, percent growth inhibition at one concentration: 68.2%
For compound 4 the middle estimate is 12.2 percentage points below the measured one; the measured number lies above the stated range.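

In this assay, fluoro in place of hydrogen on an aromatic carbon gives a number 8.3 percentage points lower from compound 1 to compound 4 (within the scatter). Set beside the step for the same change on the other core, this one cannot be told apart from it: the same change on two cores in this assay, a number 21.4 percentage points lower (beyond the scatter) from compound 2 to compound 3 and a number 8.3 percentage points lower (within the scatter) from compound 1 to compound 4, 13.1 percentage points apart, within the scatter of two such steps. Among the compounds shown here, this shows no measured difference between the two cores in how they take the change, but it does not show that the step carries over at a fixed size, as one step lies beyond the scatter, the other lies within it, and only two pairs bear on the question.

The compounds shown leave open whether a different group at the same place, such as chloro, methoxy or an amine, would give a step like these, and whether fluoro elsewhere on the ring would do so. On these data alone, whether a third core would take the fluoro change within the same span also remains open.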